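The source may report more compounds than this note shows. Statements on the series, on what has been measured and on what is new or still open speak of the compounds shown alone.

Of the compounds shown here, three have so far been tested in a functional assay on RAW264.7 cells (Mus musculus) for inhibition, read by Griess assay, with a stated time of 20 h; on this read-out lower numbers stand for stronger inhibition and higher numbers for weaker inhibition. Compound 1 `CCCNC(=O)c1cc(-n2cc(-c3cccc(Cl)c3)nn2)ccc1O` gives in this assay only a limit of the assay, > 20000 nM. Compound 2 `CCCNC(=O)c1cc(-n2cc(-c3cc(F)cc(F)c3)nn2)ccc1O` likewise gives only a limit, > 20000 nM. Compound 3 `O=C(c1ccc(-n2cc(-c3cccc(Cl)c3)nn2)cc1O)N1CCCCC1` also gives only a limit, > 20000 nM. Compound 2 differs from compound 1 by one change, (3,5-difluorophenyl in place of 3-chlorophenyl on an aromatic carbon), and the step that the two limits leave unreadable from compound 1 to compound 2 is left unreadable, as all three values sit at the limit of > 20000 nM in this assay, at which 3 of the 3 values shown sit. How the core of compound 3 differs from the core of compound 1 is not broken down here. Going by the values given here, compound 4 `O=C(c1ccc(-n2cc(-c3cc(F)cc(F)c3)nn2)cc1O)N1CCCCC1` is not yet measured; it differs from compound 3 by 3,5-difluorophenyl in place of 3-chlorophenyl on an aromatic carbon, the same change as the one from compound 1 to compound 2, made at the same place. With that step unreadable, no size can be carried over, and with compound 3 already at the limit, compound 4 is expected to remain there, the estimated step being a step that the limit leaves unreadable from compound 3 to compound 4. The estimate for compound 4 in this assay is 30000 nM.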

Compound 4, half-maximal inhibitory concentration: > 20000 nM
Compound 4: only a limit was reported (the forecaster's own chance of this, stated with the estimate: 90%); the middle value does not contradict the limit.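

No size can be read for the change from compound 3 to compound 4, because both compounds give only a limit, and the same holds for all the compounds shown: the limit of > 20000 nM in this assay, at which 4 of the 4 values shown sit. The compounds shown leave open how strongly any of them inhibits, and whether 3,5-difluorophenyl in place of 3-chlorophenyl alters inhibition at all.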